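This account rests on a few compounds, and the source may have more. Where it says the series, first, only, none or still open, it means among the compounds named here.

Notes on the series. The shared core is seen in compound 1 `Cc1nc(N)c2nc(O)n(Cc3ccccc3)c2n1`, compound 2 `CCCCc1nc(N)c2nc(O)n(Cc3ccccc3)c2n1` and compound 3 `Cc1ccc(Cn2c(O)nc3c(N)ncnc32)cc1`. In a functional assay (spleen, spleen) for activation, with Mus musculus as the target (on this read-out higher numbers stand for an effect only at larger amounts of compound and lower numbers for an effect already at smaller amounts), compound 1 gives 1 uM, compound 2 gives 0.03 uM and compound 3 gives 10 uM. Compound 2 stands lowest of the three measured numbers, with compound 1 nearest and compound 3 furthest. Among the measured compounds shown here, the single measured step, a 33-fold lower number from compound 1 to compound 2 (1.52 log units; beyond the scatter), is large. Compound 4 `CCCCSc1nc(N)c2nc(O)n(Cc3ccccc3)c2n1` differs from compound 2 by butylsulfanyl in place of butyl on an aromatic carbon. For the measured compounds named here, no measured step varies the atom joining the chain to the ring, so that step bears only indirectly: the butyl chain is retained and the sulfur is an addition of unknown weight. A modest further lowering is expected, a step of a 3.0-fold lower number from compound 2 to compound 4 (0.48 log units; beyond the scatter). Compound 4 is estimated at 0.01 uM, with a range of 0.001 uM to 0.1 uM.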

Compound 4, minimum effective concentration: 0.01 uM
Estimate against measurement, compound 4: no gap at the digits printed, within the range that was stated.
By their numbers in this assay, from the lowest: compound 4; then compound 2; then compound 1; then compound 3.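

In this assay, the position between two ring nitrogen atoms accepts sulfur as the link to the butyl chain with no loss, and the step is a 3.0-fold lower number from compound 2 to compound 4 (0.48 log units; beyond the scatter). Against methyl, the whole change reads a 100-fold lower number from compound 1 to compound 4 (2.00 log units; beyond the scatter), with most of that size already reached with butyl alone. No measurement given accounts for the gain from the sulfur link.

On these data alone, whether the sulfur atom itself or only the longer link matters stays open. Butoxy, butylamino and a longer chain such as hexylsulfanyl at this position would separate these readings.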